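Removing the aryl ring from the alkyne of compound 2

The compounds below may be only part of what the source reports. "The series", "measured", "known", "first", "only" and "open" are said of these compounds alone.

Of the compounds shown here, three have been measured in a functional assay on MCF7 cells (Homo sapiens) for antiproliferative activity, read by MTT assay, with a stated time of 72 h; a lower number here means a stronger inhibitor, a higher number a weaker inhibitor. Compound 1 `CCCCCc1ccc(C#Cc2cn(CCC(COC(C)=O)COC(C)=O)c(=O)n(C(=O)c3ccccc3)c2=O)cc1`, which carries both acetylated hydroxyls and a benzoyl group on the shared core, gives 100 nM. Compound 2 `O=c1[nH]c(=O)n(CCC(CO)CO)cc1C#Cc1ccc(Br)cc1` gives 46000 nM, and compound 3 `CCCCCc1ccc(C#Cc2cn(CCC(CO)CO)c(=O)[nH]c2=O)cc1` gives 26800 nM. Compound 2 stands highest of these three numbers; the nearest is compound 3, and the step of a 1.7-fold lower number from compound 2 to compound 3 (0.23 log units; within the scatter) is within the scatter, while compound 1 lies far below both.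

Compound 4 `CCCCCC#Cc1cn(CCC(CO)CO)c(=O)[nH]c1=O` has not yet been measured. It differs from compound 2 in one place: pentyl in place of 4-bromophenyl on a triple-bonded carbon. Within the data shown here, no measured step covers exactly this change. Among the measured compounds shown here, the only single-point step available, from compound 2 to compound 3, is within the scatter, and it exchanges a substituent on the ring rather than the ring itself, so it bears only loosely on the present question.

For the measured compounds named here, with no step to lean on, the expectation for compound 4 rests on compound 2 at 46000 nM, and a step of a 1.3-fold higher number from compound 2 to compound 4 (0.12 log units; within the scatter) is estimated, essentially no change beyond the scatter. Compound 4 is therefore expected to give about 60000 nM in this assay, within a range from 15000 nM to 200000 nM.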

Compound 4, half-maximal inhibitory concentration: 37800 nM
The estimate for compound 4 lay 1.6-fold (0.20 log units) above the measured number; the range from low to high includes it.
By their numbers in this assay, from the lowest: compound 1; then compounds 3, 4 and 2 (each within the scatter of the next).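

In this assay, a 1.2-fold lower number from compound 2 to compound 4 (0.09 log units; within the scatter) lies within the scatter, so on this triple-bonded carbon the 4-bromophenyl group, with its six-membered aromatic ring of carbon only, gives way to a pentyl chain with no ring and the read-out shows no change. The earlier step from compound 2 to compound 3 exchanged only the substituent on that ring and left the ring in place, whereas this one removes the ring itself, and among compounds 2, 3 and 4 the ring proves not to be required for the number to stay where it stands. No measured evidence is at hand to explain why this exchange leaves the number unchanged.

The compounds shown leave open whether any other group on this carbon would move the number, such as a longer chain, an amine or a carboxylic acid in place of pentyl. They also leave open whether the ring can be given up as freely in the acetylated and benzoylated form seen in compound 1 , which gives 100 nM in this assay, since all of the evidence on this change comes from the compounds with free hydroxyls.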